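Trimming a benzyl to methyl on an inactive scaffold

The source may report more compounds than this note shows. Statements on the series, on what has been measured and on what is new or still open speak of the compounds shown alone.

Compound 2 `CS(=O)(=O)c1ccc(C(=O)NCC(=O)N(Cc2ccccc2)Cc2ccccc2)cc1[N+](=O)[O-]` stands at the edge of what the measurement reports: in an assay on isolated protein for inhibition of vitamin D3 receptor (Homo sapiens), read by fluorescence polarization (on this read-out higher numbers stand for weaker inhibition and lower numbers for stronger inhibition), compound 2 gives > 60000 nM, a limit rather than a number. Compound 1 `CS(=O)(=O)c1ccc(C(=O)N2CCC(C(=O)N(Cc3ccccc3)c3ccccc3)CC2)cc1[N+](=O)[O-]` also sits at a limit, giving > 60000 nM in this assay. Both values share (the limit of > 60000 nM in this assay, at which 2 of the 2 values shown sit). Compound 3 `CN(Cc1ccccc1)C(=O)CNC(=O)c1ccc(S(C)(=O)=O)c([N+](=O)[O-])c1` differs from compound 2 by hydrogen in place of phenyl on a saturated chain carbon bound to an amide-type nitrogen. Among the measured compounds shown here, no step between measured compounds is known, so no change beyond the scatter is expected in this assay. Compound 3 is estimated at 100000 nM, between 40000 nM and 300000 nM. The expected step is a step that the limit leaves unreadable from compound 2 to compound 3.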

Compound 3, half-maximal inhibitory concentration: > 60000 nM
Compound 3: no number, only a limit (the forecaster's own chance of this, stated with the estimate: 85%); the middle value is on the limit's open side.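

Compound 2 and compound 3 both sit at a limit rather than a number, and no step can be read between them. The compounds shown leave open whether benzyl to methyl changes the read-out at all.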